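A few compounds are considered here, and "the series" means these few. Any claim that something is new, unique, unknown or untested is made for them only; others in the source may bear on it.

Compound 1 `Cc1cc([C@@H]2C[C@H]2C(=O)O)ccc1-c1noc(-c2ccc(OC(C)C)c(C(F)(F)F)c2)n1`: 6.3 h
Compound 2 `Cc1cc([C@@H]2C[C@H]2C(=O)O)ccc1-c1noc(-c2ccc(OC(C)C)c(C#N)c2)n1`: 4.9 h; 5.9 h (2 entries)

Going by the values given here, in an in vivo ADME assay on the whole organism (strain Sprague-Dawley) for metabolic stability, with Rattus norvegicus as the target (on this read-out lower numbers stand for a shorter-lived compound and higher numbers for a longer-lived compound), compound 1 stands at 6.3 h, its only single number, and one further entry gives no single figure. Compound 1 and compound 2 lie within the usual scatter of each other.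

Compound 3 `Cc1cc(CC(C)C(=O)O)ccc1-c1noc(-c2ccc(OC(C)C)c(C(F)(F)F)c2)n1` keeps the core of compound 1 but carries 2-carboxypropyl in place of 2-carboxycyclopropyl on an aromatic carbon. Among the compounds with values here, no measured pair shows what this change does, so only a modest expectation is possible. The estimated 1.3-fold lower number from compound 1 to compound 3 (0.10 log units; within the scatter) is expected to stay within the scatter, with no firm direction. In this assay compound 3 is expected at 5 h, with an estimated range of 2.5 h to 10 h.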

Compound 3, half-life: 1.7 h
Compound 3: the middle estimate sits 2.9-fold (0.47 log units) above what was measured; measured number outside the range, below it.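

Replacing 2-carboxycyclopropyl with 2-carboxypropyl at this position gives, in this assay, a 3.7-fold lower number from compound 1 to compound 3 (0.57 log units; beyond the scatter). The earlier compounds differ in another place and lie within the usual scatter of each other, so this is the first change shown to move the half-life clearly. Repeat entries for a single compound lie much closer together than this step: the several entries of compound 2 in this assay, 4.9 h; 5.9 h (2 entries)

Compound 3 loses both the ring and the two defined stereocentres of compound 1, and the compounds shown do not separate the two. Also open, going by these compounds, is what a longer chain or an amide would give at this position.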